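Working notes: benzyl in place of the ring substituent

A few compounds are considered here, and "the series" means these few. Any claim that something is new, unique, unknown or untested is made for them only; others in the source may bear on it.

Measured so far in a functional assay on the whole organism (B cells) with Mus musculus as the target; a lower number here means a smaller maximal response, a higher number a larger maximal response:
- compound 1 `CCCn1c(=O)n(C2CCC(COC(C)=O)O2)c2nc(NC(C)=O)nc(O)c21` gives 100%
- compound 2 `C=CCn1c(=O)n(C2CCC(CO)C2)c2nc(N)nc(O)c21` gives 26%
- compound 3 `C=CCN1C(=C(C(=O)OCC)C(=O)OCC)N([C@H]2OC(CO)[C@H]3OC(C)(C)O[C@H]32)c2cc(N)nc(O)c21` gives 0%

Compound 2 holds the second highest of the three numbers in this assay. The nearest is compound 3, whose number lies lower by more than the usual scatter; the furthest is compound 1, whose number lies higher, again beyond the scatter. Within the data shown here, no pair of measured compounds differs in one place only, so no single step between them can be read off.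

Compound 4 `C=CCn1c(=O)n(Cc2ccccc2)c2nc(N)nc(O)c21` is the next candidate for this assay. Its change from compound 2: a group of 7 heavy atoms (7 carbon; one six-membered aromatic ring of carbon only) in place of a group of 7 heavy atoms (6 carbon, 1 oxygen; one five-membered non-aromatic ring of carbon only), on an aromatic nitrogen. The group that leaves has a hydrogen-bond donor and a hydrogen-bond acceptor; the benzyl that enters has neither. Compound 1 gives the largest response of the three and compound 3 gives none, but neither shares this change, so no direction can be drawn from them.

The step of a number 11 percentage points lower from compound 2 to compound 4 (beyond the scatter) is expected to be a fall beyond the scatter, though not to zero. Compound 4 is estimated to reach 15% in this assay, within a range from 0% to 45%.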

Compound 4, largest response reached (reported as maximal response), in percent of the reference or control that the assay uses: 25%
For compound 4 the middle estimate is 10 percentage points below the measured one; the measured number falls inside the stated range.
By their numbers in this assay, from the lowest: compound 3; then compounds 4 and 2 (each within the scatter of the next); then compound 1.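

In this assay the step is a number 1 percentage points lower from compound 2 to compound 4 (within the scatter) and gives the series its first comparison in one place. On the aromatic nitrogen, benzyl, which has no hydrogen-bond donor or acceptor, stands in place of a five-membered non-aromatic ring group that has one of each, and the response stays within the scatter, so in this pair the donor and acceptor of the leaving group are not needed to keep the response at this level. No measurement shown here accounts for this result.

Still open, on these data alone, is whether the response at this nitrogen holds with a much smaller group such as methyl, or with a longer chain such as phenethyl. Also open, as far as these compounds go, is whether an amine or a carboxylic acid on the benzyl ring would shift it.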